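Replacing a Pentyl Selenide with a Free Selenol

The source may hold more compounds than are shown below. What is called first, only, known or untested is meant among the compounds shown, and "the series" means these compounds.

Compound 2 `CCCCC[Se]c1nc(NCc2ccc(SC)cc2)c2ccccc2n1` carries a pentyl chain on its selenium. In a functional assay on HT-29 cells (Homo sapiens) for cytotoxicity, read by MTT assay, with a stated time of 72 h (on this read-out higher numbers stand for lower toxicity in this test and lower numbers for higher toxicity in this test), compound 2 gives only a limit of the test, > 100000 nM. A related compound 1 `COc1ccc(CNc2nc([SeH])nc3ccccc23)cc1` also gives only a limit in this assay, > 100000 nM. Compound 2 thus stands where every number shown stands, at the limit of > 100000 nM in this assay, at which 2 of the 2 values shown sit. The compound still to be measured, compound 3 `CSc1ccc(CNc2nc([SeH])nc3ccccc23)cc1`, differs from compound 2 in one place: hydrogen in place of pentyl on a selenium. Within the data shown here, no step between two measured compounds is available, so the effect of this change cannot be read from a measured pair. Compound 1 also bears hydrogen on selenium and reaches only a limit. For that reason the step from compound 2 to compound 3 a step that the limit leaves unreadable from compound 2 to compound 3 is expected to be none beyond the scatter. Compound 3 is therefore estimated at 150000 nM, within a likely range from 60000 nM to 400000 nM, most probably reported again only as a limit.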

Compound 3, concentration lethal to 50% of the cells: > 100000 nM
Compound 3 gave a limit, no number; the forecaster's own chance of this, stated with the estimate: 80%; the middle value is on the limit's open side.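

No new step can be read from compound 2 to compound 3 or from compound 1 to compound 3, because all three compounds stop at a limit: the limit of > 100000 nM in this assay, at which 3 of the 3 values shown sit.

The compounds shown leave open whether in this assay hydrogen in place of pentyl on a selenium, or methylsulfanyl in place of methoxy on an aromatic carbon, changes the read-out at all.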